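A few compounds are considered here, and "the series" means these few. Any claim that something is new, unique, unknown or untested is made for them only; others in the source may bear on it.

Measured compounds:
Compound 1 `Brc1cccc(CSc2nnc(-c3cnccn3)s2)c1`: in a functional assay on HepG2 cells (Homo sapiens) for antiproliferative activity, read by MTT assay, with a stated time of 48 h (a lower number here means a stronger inhibitor, a higher number a weaker inhibitor), compound 1 gives 1790 nM.
Compound 2 `Clc1ccccc1CSc1nnc(-c2cnccn2)n1-c1ccccc1`: in this assay compound 2 gives 18800 nM.

Going by the values given here, compound 2 stands at the higher of the two numbers; compound 1 sits well below it, a gap beyond the usual scatter, but the two differ in more than one place and no single step joins them. Compound 3 `c1ccc(CSc2nnc(-c3cnccn3)n2-c2ccccc2)cc1` is not yet measured. It differs from compound 2 by hydrogen in place of chloro on an aromatic carbon. Among the compounds with values here, no step of this kind has been measured, so only a small effect, none beyond the scatter, is expected in this assay. Compound 3 is expected to give about 22000 nM in this assay, from 8000 nM to 60000 nM. The step of a 1.2-fold higher number from compound 2 to compound 3 (0.07 log units; within the scatter) is expected to stay within the scatter.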

Compound 3, half-maximal inhibitory concentration: 17100 nM
Compound 3: the middle estimate sits 1.3-fold (0.11 log units) above what was measured; measured number inside the range.
By their numbers in this assay, from the lowest: compound 1; then compounds 3 and 2 (each within the scatter of the next).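

In this assay hydrogen in place of chloro on an aromatic carbon, ortho to a large group, gives a 1.1-fold lower number from compound 2 to compound 3 (0.04 log units; within the scatter) and so, in this series, 2-chlorobenzyl and benzyl cannot be told apart. This is the only single-place step among the compounds shown, and it concerns this one position alone. Nothing measured here bears on why the two compounds read alike.

On these data alone, whether a methoxy group or an amine at this position would read differently remains open. Compound 1 differs from compound 2 and compound 3 in more than one place, so no single change can be credited with its separation from them.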